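The source may hold more compounds than are shown below. What is called first, only, known or untested is meant among the compounds shown, and "the series" means these compounds.

In an ADME assay on a cell-free system (plasma, Homo sapiens) for metabolic stability, read by LC-MS (on this read-out lower numbers stand for a shorter-lived compound and higher numbers for a longer-lived compound), compound 1 `CCCCOC(=O)c1cccc(NC(=O)c2cccc(-c3cc(C(=O)Nc4ccncc4F)ccc3CN)c2)c1` gives < 0.0834 h, which is a limit of the assay and not a number. For the measured compounds named here, compound 2 `CC(C)OC(=O)c1cccc(NC(=O)c2cccc(-c3cc(C(=O)Nc4ccncc4F)ccc3CN)c2)c1` gives 0.567 h, the only true number so far in this assay. Compound 3 `CCC(C)OC(=O)c1cccc(NC(=O)c2cccc(-c3cc(C(=O)Nc4ccncc4F)ccc3CN)c2)c1` differs from compound 2 by methyl in place of hydrogen on a saturated chain carbon, two bonds along the chain from an oxygen next to a carbonyl group, which turns isopropyl to sec-butyl. Going by the values given here, only one measured step bears on this chain, an at least 6.7-fold higher number from compound 1 to compound 2 (0.83 log units; beyond the scatter). On these data alone, that step is large, but it is open-ended and is a different change, so it gives no direct size for this one. With compound 3 keeping a branched chain like compound 2, no shift beyond the scatter is expected, and the estimated step is a 1.1-fold higher number from compound 2 to compound 3 (0.02 log units; within the scatter). For compound 3 the expected half-life is 0.6 h, with an estimated range of 0.25 h to 1.5 h.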

Compound 3, half-life: 0.267 h
For compound 3 the middle estimate is 2.2-fold (0.35 log units) above the measured one; the measured number falls inside the stated range.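

In this assay, a branched chain on this oxygen does not by itself settle the half-life: methyl in place of hydrogen on a saturated chain carbon, two bonds along the chain from an oxygen next to a carbonyl group, gives a 2.1-fold lower number from compound 2 to compound 3 (0.33 log units; beyond the scatter). Sec-butyl nevertheless stands apart from the unbranched butyl, with an at least 3.2-fold higher number from compound 1 to compound 3 (0.50 log units; beyond the scatter). That step is open-ended because compound 1 stands at a limit and not a number: the limit of < 0.0834 h in this assay, at which 1 of the 3 values shown sits.

The compounds shown leave open how a tert-butyl or a cyclopentyl group on the same oxygen would compare with isopropyl and sec-butyl. They also leave open whether an amide in place of the ester would follow the same order among these chains.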